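A few compounds are considered here, and "the series" means these few. Any claim that something is new, unique, unknown or untested is made for them only; others in the source may bear on it.

Of the compounds shown here, three on the shared core have been measured in an assay on isolated protein for displacement of a labelled ligand from metabotropic glutamate receptor 5 (Homo sapiens), with a stated time of 60 min, tested at 1 uM; a higher number here means more inhibition at the concentration tested (going by the name of the read-out), a lower number less inhibition. Compound 1 `Cc1ccc2ncc(S(=O)(=O)c3cccc(C#N)c3)c(N3CCC(C)CC3)c2c1` gives 52%. Compound 2 `Cc1ccc2ncc(S(=O)(=O)c3ccc(F)c(Cl)c3)c(N3CCC(C)CC3)c2c1` gives 93%, and compound 3 `Cc1ccc2ncc(S(=O)(=O)c3cccc(F)c3)c(N3CCC(C)CC3)c2c1` gives 94%. Compound 3 stands together with compound 2, the two within the scatter of each other, and well apart from compound 1: a number 42 percentage points higher from compound 1 to compound 3 (beyond the scatter), a number 41 percentage points higher from compound 1 to compound 2 (beyond the scatter), whereas a number 1 percentage points higher from compound 2 to compound 3 (within the scatter). Compound 4 `Cc1ccc2ncc(S(=O)(=O)c3ccc(Cl)cc3)c(N3CCC(C)CC3)c2c1` differs from compound 3 as follows: 4-chlorophenyl in place of 3-fluorophenyl on a sulfonyl sulfur. For the measured compounds named here, no measured step exchanges one halogen for another alone; the nearest, from compound 2 to compound 3, stayed within the scatter, while both large steps replaced cyano. A step within the scatter is therefore expected in this assay: a number 9 percentage points lower from compound 3 to compound 4 (within the scatter). Compound 4 is expected to give 85%, in the range 60% to 97%.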

Compound 4, a percentage reported as inhibition, at one concentration (the size of the read-out at that concentration, not a potency): 79%
Compound 4: middle estimate off by 6 percentage points, on the high side; low and high end bracket the measured number.
By their numbers in this assay, from the lowest: compound 1; then compound 4; then compounds 2 and 3 (each within the scatter of the next).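

Changing between halogen-bearing aryl groups on the sulfonyl sulfur can move the read-out in this assay beyond the scatter (a number 15 percentage points lower from compound 3 to compound 4 (beyond the scatter); a number 14 percentage points lower from compound 2 to compound 4 (beyond the scatter)), which the earlier halogen-bearing pair did not show. The 4-chlorophenyl group still reads well above 3-cyanophenyl (a number 27 percentage points higher from compound 1 to compound 4 (beyond the scatter)), so compound 4 falls in the gap left between the earlier values. Nothing available explains this ordering.

Whether the change follows the chlorine or where it sits on the ring remains unresolved. Compounds carrying 3-chlorophenyl or 4-fluorophenyl at this sulfonyl sulfur would separate the two.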